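This account rests on a few compounds, and the source may have more. Where it says the series, first, only, none or still open, it means among the compounds named here.

Three compounds share one core and were compared in a functional assay on HepG2 cells (Homo sapiens) for antiproliferative activity, read by CCK-8 assay, with a stated time of 72 h, tested at 2 uM; on this read-out lower numbers stand for a weaker effect and higher numbers for a stronger effect at the one concentration tested. Compound 1 `CC1CCN(c2nc(Cl)nc3c2ncn3Cc2ccc(/C=C/C(=O)Nc3ccccc3N)cc2)CC1` gives 8.73%. Compound 2 `Cc1ccc(Nc2nc(Cl)nc3c2ncn3Cc2ccc(/C=C/C(=O)Nc3ccccc3N)cc2)cc1` gives 33.6%. Compound 3 `Nc1ccccc1NC(=O)/C=C/c1ccc(Cn2cnc3c(Nc4cccc(OC(F)(F)F)c4)nc(Cl)nc32)cc1` gives 16.2%, which is the second highest of the three numbers: its nearest neighbour is compound 1, and the two lie within the scatter, while compound 2 lies beyond the scatter above it. The three steps measured so far are a number 24.9 percentage points higher from compound 1 to compound 2 (beyond the scatter), a number 7.5 percentage points higher from compound 1 to compound 3 (within the scatter) and a number 17.4 percentage points lower from compound 2 to compound 3 (beyond the scatter).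

Compound 4 `Nc1ccccc1NC(=O)/C=C/c1ccc(Cn2cnc3c(NC4CCCCC4)nc(Cl)nc32)cc1` differs from compound 3 by cyclohexyl in place of 3-(trifluoromethoxy)phenyl on a nitrogen on an aromatic ring. The step from compound 2 to compound 3 bears on it most closely, as it also exchanges the group on that nitrogen, and it was modest; the steps from compound 1, which carries a non-aromatic ring directly on the aromatic carbon, were within the scatter or modest. Within the data shown here, no measured step exchanges an aromatic ring for a cyclohexyl on this nitrogen, so the direction is uncertain, and a step of a number 2.2 percentage points lower from compound 3 to compound 4 (within the scatter) in this assay is expected, at most modest. Compound 4 is therefore estimated at 14%, within a range from 3% to 32%.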

Compound 4, a percentage reported as inhibition, at one concentration (the size of the read-out at that concentration, not a potency): 3.83%
The estimate for compound 4 lay 10.2 percentage points above the measured number, and the stated range covers the measured number.
By their numbers in this assay, from the lowest: compounds 4, 1 and 3 (each within the scatter of the next, the first and the last beyond it); then compound 2.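

In this assay, replacing an aromatic ring with cyclohexyl on this nitrogen gives a number 12.4 percentage points lower from compound 3 to compound 4 (beyond the scatter), and the same kind of change starting from 4-methylphenyl gives a number 29.8 percentage points lower from compound 2 to compound 4 (beyond the scatter). With a number 4.9 percentage points lower from compound 1 to compound 4 (within the scatter), cyclohexylamino and 4-methylpiperidin-1-yl cannot be told apart on this aromatic carbon, and across the four compounds the groups with and without an aromatic ring separate beyond the scatter in every pair except compound 1 and compound 3, which go against this pattern. No measurement shown accounts for these differences.

The compounds shown leave open whether a smaller ring such as cyclopentyl or an open chain such as n-butyl on this nitrogen would read like cyclohexyl. They also leave open how a benzyl group or a pyridyl ring would compare with the phenyl groups of compound 2 and compound 3.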